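Replacing iodo with formyl in compound 2

A few compounds are considered here, and "the series" means these few. Any claim that something is new, unique, unknown or untested is made for them only; others in the source may bear on it.

Compound 1 `O=c1cc(I)n([C@@H]2O[C@H](CO)[C@@H](O)[C@H]2O)c(=O)[nH]1`: 18900 nM
Compound 2 `O=c1[nH]c(=O)n([C@@H]2O[C@H](CO)[C@@H](O)[C@H]2O)c(I)c1F`: > 50000 nM

Both values come from a functional assay on SKW3 cells (Homo sapiens) for antiproliferative activity, read by WST assay, with a stated time of 3 days; a lower number here means a stronger inhibitor, a higher number a weaker inhibitor. Compound 2 stands at > 50000 nM, which is a limit of the assay and not a number. Compound 3 `O=Cc1c(F)c(=O)[nH]c(=O)n1[C@@H]1O[C@H](CO)[C@@H](O)[C@H]1O` carries formyl in place of iodo on an aromatic carbon. Going by the values given here, the one measured step, an at least 2.6-fold higher number from compound 1 to compound 2 (0.42 log units; beyond the scatter), puts fluoro in place of hydrogen and leaves the iodo untouched, so it gives neither size nor direction for this change. The expected step is therefore none beyond the scatter, with an at least 1.1-fold lower number from compound 2 to compound 3 (0.04 log units; that floor lies within the scatter) as the estimate. Compound 3 is estimated at 45000 nM, with an expected range of 12000 nM to 150000 nM.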

Compound 3, half-maximal inhibitory concentration: 300 nM
Estimate against measurement, compound 3: 150-fold (2.18 log units) above, outside the stated range (below it).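

The earlier compounds shown here changed only the fluoro and kept the iodo, so they said nothing about this position. In this assay, formyl in place of iodo on this aromatic carbon, next to the ring nitrogen and ortho to a fluoro group, gives an at least 160-fold lower number from compound 2 to compound 3 (2.22 log units; beyond the scatter). Compound 2 stands at a limit of the assay and not a number, so this size is only a floor: the limit of > 50000 nM in this assay, at which 1 of the 3 values shown sits.

The compounds shown leave open whether formyl gives a similar gain with hydrogen in place of the fluoro group. They also leave open how a carboxylic acid, a nitrile or an amine at this position would compare with formyl.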